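Chloro substitution on the pyrazolyl-bearing ring of compound 1

The compounds below may be only part of what the source reports. "The series", "measured", "known", "first", "only" and "open" are said of these compounds alone.

Compound 1 `c1cc(-c2cn[nH]c2)c2c(c1)C(c1ncc[nH]1)CC2` stands at the limit of a functional assay on CHO cells for agonist activity at Alpha-1B adrenergic receptor (Homo sapiens), read by FLIPR and calcium flux; a lower number here means that less compound is needed, a higher number that more compound is needed for the effect: compound 1 gives > 10000 nM, which is a limit of the assay and not a number. Compound 2 `c1ccc(-c2cccc3c2CCC3c2ncc[nH]2)nc1` likewise gives only a limit in this assay, > 10000 nM. Among the measured compounds shown here, the one measured step, a step that the two limits leave unreadable from compound 1 to compound 2, is therefore unreadable, since both of its ends sit at the limit (the limit of > 10000 nM in this assay, at which 2 of the 2 values shown sit). Compound 3 `Clc1ccc2c(c1-c1cn[nH]c1)CCC2c1ncc[nH]1` differs from compound 1 by chloro in place of hydrogen on an aromatic carbon. For the measured compounds named here, no measured step touches this position, so nothing speaks for a readable change here. With compound 1 at the limit, the expected step that the limit leaves unreadable from compound 1 to compound 3 can only be stated as an expectation that compound 3 again shows no measurable potency in this assay. Compound 3 is expected to give 20000 nM, with a range from 5000 nM to 100000 nM, most likely reported only as a limit.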

Compound 3, half-maximal effective concentration: > 10000 nM
Compound 3 was reported as a limit (the forecaster's own chance of this, stated with the estimate: 85%); the middle value lies beyond the limit too.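

Compound 3, like compound 1, stands at a limit in this assay, so no step can be read between compound 1 and compound 3. The compounds shown leave open what chloro in place of hydrogen does to potency, as none gives a number for comparison.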